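A methoxycarbonyl on the amino group of compound 3

A few compounds are considered here, and "the series" means these few. Any claim that something is new, unique, unknown or untested is made for them only; others in the source may bear on it.

Of the compounds shown here, three sharing one core have been tested in a functional assay on aorta (Rattus norvegicus, strain Sprague-Dawley); on this read-out higher numbers stand for an effect only at larger amounts of compound and lower numbers for an effect already at smaller amounts. Compound 1 `Cc1nn(-c2ccccc2)c2nc(OCc3ccccc3F)c(-c3nc(N)c(N4CCCCC4)c(N)n3)cc12` gives 790 nM, and compound 3 `Cc1nn(-c2ccccc2)c2nc(OCc3ccccc3F)c(-c3nc(N)c(N)c(N)n3)cc12` gives 960 nM, two values within the scatter of each other. Compound 2 `Cc1nn(-c2ccccc2)c2nc(OCc3ccccc3F)c(-c3nc(N)c(N4CCCC4)c(N)n3)cc12` gives 12700 nM, clearly the highest number of the three. Compound 3 therefore sits level with compound 1, at the low end of this small set.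

Compound 4 `COC(=O)Nc1c(N)nc(-c2cc3c(C)nn(-c4ccccc4)c3nc2OCc2ccccc2F)nc1N` differs from compound 3 by one change: methoxycarbonyl in place of hydrogen on a nitrogen on an aromatic ring. This is methoxycarbonyl in place of hydrogen on a nitrogen on an aromatic ring, so amino becomes (methoxycarbonyl)amino. Going by the values given here, no measured step adds this group. The closest evidence comes from the groups that stand in place of that amino group in the other two compounds. There, a 1.2-fold higher number from compound 1 to compound 3 (0.08 log units; within the scatter) and a 13-fold lower number from compound 2 to compound 3 (1.12 log units; beyond the scatter). Such swaps have thus given both no visible step and a large one, so the direction stays open. For this assay, no step beyond the scatter is the expected outcome, though with wide uncertainty.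

The estimated step is a 1.3-fold higher number from compound 3 to compound 4 (0.10 log units; within the scatter). For compound 4 the expected value is 1200 nM, with an estimated range from 250 nM to 6000 nM.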

Compound 4, half-maximal effective concentration: 5800 nM
Compound 4: the middle estimate sits 4.8-fold (0.68 log units) below what was measured; measured number inside the range.
By their numbers in this assay, from the lowest: compounds 1 and 3 (each within the scatter of the next); then compound 4; then compound 2.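

In this assay, methoxycarbonyl on this amino nitrogen brings a 6.0-fold higher number from compound 3 to compound 4 (0.78 log units; beyond the scatter) and so shows that a small addition here can move the number beyond the scatter. Amino and piperidin-1-yl could not be told apart at this position, but (methoxycarbonyl)amino stands clear of both, with a 7.3-fold higher number from compound 1 to compound 4 (0.87 log units; beyond the scatter) and with a 2.2-fold lower number from compound 2 to compound 4 (0.34 log units; beyond the scatter) as its place relative to the pyrrolidin-1-yl compound. No measurement is available that would explain these steps.

The compounds shown leave open whether the shift follows the carbonyl or the whole methoxycarbonyl group, which acetyl or methyl on the same nitrogen would help to separate. They also leave open how a longer chain such as ethoxycarbonyl, or another ring such as morpholin-4-yl in place of the amino group, would read out.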